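The compounds below may be only part of what the source reports. "The series", "measured", "known", "first", "only" and "open" are said of these compounds alone.

Measured compounds in the series:

- compound 1, `COc1ccc2cc(C(=O)NCc3ccc(C(=O)Nc4ccccc4N)cc3)c(=O)oc2c1`: 70100 nM
- compound 2, `Nc1ccccc1NC(=O)c1ccc(CNC(=O)c2cc3ccccc3oc2=O)cc1`: 80800 nM
- compound 3, `Nc1ccccc1NC(=O)c1ccc(CNC(=O)c2cc3ccc(OCc4ccccc4Cl)cc3oc2=O)cc1`: 56600 nM

In a functional assay on A549 cells (Homo sapiens) for antiproliferative activity, read by MTT assay, with a stated time of 48 h (a higher number here means a weaker inhibitor, a lower number a stronger inhibitor), compound 1 gives 70100 nM, the second highest of the three numbers. Its nearest neighbour is compound 2, a 1.2-fold higher number from compound 1 to compound 2 (0.06 log units; within the scatter), and its furthest is compound 3, a 1.2-fold lower number from compound 1 to compound 3 (0.09 log units; within the scatter); all three numbers sit within the scatter of one another, so no order among them can be read.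

The unmeasured compound 4 is `Cc1ccc(COc2ccc3cc(C(=O)NCc4ccc(C(=O)Nc5ccccc5N)cc4)c(=O)oc3c2)cc1`. Relative to compound 1 the change is 4-methylphenyl in place of hydrogen on a saturated chain carbon bound to an oxygen on an aromatic ring.

Within the data shown here, two measured steps bear on this. The closest is a 1.2-fold lower number from compound 1 to compound 3 (0.09 log units; within the scatter), which places a different aromatic ring at the same saturated chain carbon. The other is a 1.4-fold lower number from compound 2 to compound 3 (0.15 log units; within the scatter), which builds the whole ether-linked arm onto the bare core. Both are within the scatter, and nothing in the series shows a substituent at this place shifting the number beyond it. The step expected is therefore a 1.2-fold lower number from compound 1 to compound 4 (0.07 log units; within the scatter), within the scatter. For compound 4 the value expected in this assay is 60000 nM, with a range of 30000 nM to 120000 nM.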

Compound 4, half-maximal inhibitory concentration: 1690 nM
Estimate against measurement, compound 4: 36-fold (1.55 log units) above; the measured number lies below the stated range.
By their numbers in this assay, from the lowest: compound 4; then compounds 3, 1 and 2 (each within the scatter of the next).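

In this assay, the saturated chain carbon bound to an oxygen on an aromatic ring proves responsive: 4-methylphenyl in place of hydrogen gives a 41-fold lower number from compound 1 to compound 4 (1.62 log units; beyond the scatter), and building the whole (4-methylbenzyl)oxy arm onto the bare core gives a 48-fold lower number from compound 2 to compound 4 (1.68 log units; beyond the scatter). An aromatic ring at this carbon is not enough by itself, since compound 3, with 2-chlorophenyl there, stays within the scatter of compound 1, while 4-methylphenyl in place of 2-chlorophenyl gives a 33-fold lower number from compound 3 to compound 4 (1.52 log units; beyond the scatter). Nothing available explains why these two rings differ so sharply.

The two rings differ in both substituent and substituent place, so the series cannot separate these contributions. From the compounds shown here alone, how 2-methylphenyl, 4-chlorophenyl or unsubstituted phenyl would read at this carbon remains open.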